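This account rests on a few compounds, and the source may have more. Where it says the series, first, only, none or still open, it means among the compounds named here.

Measured so far:

- compound 1, `CCc1cncc(OC[C@@H]2CCCN2C)c1`: 0.32 nM
- compound 2, `CCCc1cncc(OC[C@@H]2CCCN2C)c1`: 0.12 nM

Both compounds share the same core and differ only in the length of a saturated chain attached to an aromatic carbon. Among the compounds with values here, in an assay on membranes from brain for displacement of a labelled ligand from Neuronal acetylcholine receptor; alpha4/beta2 (Rattus norvegicus) (a higher number here means a weaker inhibitor, a lower number a stronger inhibitor), compound 1 gives 0.32 nM, while compound 2 gives 0.12 nM, the lower of the two numbers and therefore the stronger binder; the only step measured, a 2.7-fold lower number from compound 1 to compound 2 (0.43 log units; beyond the scatter), lies beyond the scatter but is modest.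

Compound 3, `CC(C)Cc1cncc(OC[C@@H]2CCCN2C)c1`, continues along the same chain: methyl in place of hydrogen on a saturated chain carbon bound to two saturated chain carbons. Within the data shown here, the one measured step bears on it directly, since it also added a methyl group to the chain, and it lowered the number in this assay by a modest amount. Adding a further methyl at a carbon already bound to two chain carbons is not the same as lengthening the chain, so a change of similar or smaller size is expected, most likely downward or not beyond the scatter at all. Compound 3 is therefore expected to give about 0.1 nM, with a range from 0.03 nM to 0.4 nM. That corresponds to an expected 1.2-fold lower number from compound 2 to compound 3 (0.08 log units; within the scatter).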

Compound 3, inhibition constant: 0.21 nM
For compound 3 the middle estimate is 2.1-fold (0.32 log units) below the measured one; the measured number falls inside the stated range.
By their numbers in this assay, from the lowest: compounds 2, 3 and 1 (each within the scatter of the next, the first and the last beyond it).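

In this assay the methyl that turns propyl into isobutyl, on a saturated chain carbon bound to two saturated chain carbons, gives a 1.8-fold higher number from compound 2 to compound 3 (0.24 log units; within the scatter) and so leaves compound 3 impossible to tell apart from compound 2. The same holds on the other side, where the change from ethyl to isobutyl gives a 1.5-fold lower number from compound 1 to compound 3 (0.18 log units; within the scatter) and compound 3 also cannot be separated from compound 1, even though the step of a 2.7-fold lower number from compound 1 to compound 2 (0.43 log units; beyond the scatter) does stand clear of the scatter. This position therefore accepts a branched chain with no firm change in the number, so compound 3 sits in the narrow gap between the other two and adds no clear gain, while nothing available explains why the branch behaves this way.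

On these data alone, three small saturated chains cover only a short stretch of what this position might hold, so it remains open whether a longer chain such as pentyl would keep the number this low. Equally open, as far as these compounds go, is how a ring such as cyclopropyl, or an amine at the end of the chain, would fare in this assay against these values.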